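One more chloro on the aromatic ring of compound 1

The compounds below may be only part of what the source reports. "The series", "measured", "known", "first", "only" and "open" are said of these compounds alone.

Measured in a functional assay on HL-60 cells (Homo sapiens) for antiproliferative activity, read by MTT assay, with a stated time of 72 h; a lower number here means a stronger inhibitor, a higher number a weaker inhibitor:
Compound 1 `NC1=NC2(CCOCC2)N(OCCCOc2ccc(Cl)cc2)C(N)=N1`: 330 nM
Compound 2 `NC1=NC2(CCSCC2)N(OCCCOc2cccc(Cl)c2Cl)C(N)=N1`: 30 nM

Of these two numbers, the higher belongs to compound 1, at 330 nM. Compound 2 gives 30 nM, and the gap between the two lies beyond the scatter, but compound 2 differs from compound 1 in more than one place, so the gap isolates no single change.

Compound 3 `NC1=NC2(CCOCC2)N(OCCCOc2ccc(Cl)cc2Cl)C(N)=N1` keeps the core of compound 1 and turns its 4-chlorophenyl into 2,4-dichlorophenyl, with chloro in place of hydrogen on an aromatic carbon, ortho to a large group: chloro in place of hydrogen on an aromatic carbon. Among the measured compounds shown here, no measured pair shows this change alone. Compound 2 also bears a dichlorophenyl group and gives 30 nM, which tilts the expectation towards a lower number. The expected move in this assay is a modest drop, estimated as a 3.0-fold lower number from compound 1 to compound 3 (0.48 log units; beyond the scatter). For compound 3 the estimated value is 110 nM, with an expected range of 35 nM to 330 nM.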

Compound 3, half-maximal inhibitory concentration: 330 nM
Compound 3: middle estimate off by 3.0-fold (0.48 log units), on the low side; the range from low to high includes it.
By their numbers in this assay, from the lowest: compound 2; then compounds 1 and 3 (each within the scatter of the next).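

In this assay, turning 4-chlorophenyl into 2,4-dichlorophenyl gives no change at the digits printed from compound 1 to compound 3 (within the scatter). Among the compounds shown here, this is the first step in the set that changes one place only, and it shows that chloro in place of hydrogen on this aromatic carbon, ortho to a large group, does not by itself move the number on the core of compound 1. Nothing measured here bears on this result.

The low value of compound 2 remains unassigned, since that compound differs from compound 1 and from compound 3 in more than one place, so its steps to them cannot be read. From the compounds shown here alone, whether fluoro, methyl, methoxy or an amine on the same aromatic carbon would shift the number also stays open, as does whether chloro there would behave the same way on the core of compound 2.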